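A few compounds are considered here, and "the series" means these few. Any claim that something is new, unique, unknown or untested is made for them only; others in the source may bear on it.

Within the data shown here, in a functional assay on MV4-11 cells (Homo sapiens) for inhibition, read by resazurin assay, with a stated time of 72 h (a lower number here means a stronger inhibitor of growth, a higher number a weaker inhibitor of growth), compound 1 `CNc1nc(C)c(-c2ccnc(Nc3ccc(OC)cc3OC)n2)s1` gives 300 nM and compound 2 `COc1ccc(Nc2nccc(-c3sc(SCCCN(C)C)nc3C)n2)c(OC)c1` gives 370 nM, so compound 2 sits within the usual scatter of the only other measured compound. Compound 3 `CCCSc1nc(C)c(-c2ccnc(Nc3ccc(OC)cc3OC)n2)s1` differs from compound 2 in one place: hydrogen in place of dimethylamino on a saturated chain carbon, three bonds along the chain from a sulfur. That is hydrogen in place of dimethylamino on a saturated chain carbon, three bonds along the chain from a sulfur. Among the measured compounds shown here, the one measured step touching this part of the structure, a 1.2-fold higher number from compound 1 to compound 2 (0.09 log units; within the scatter), stays within the scatter, so no step beyond the scatter is expected in this assay. The expected change is small: a 1.1-fold lower number from compound 2 to compound 3 (0.02 log units; within the scatter). The estimate for compound 3 is 350 nM, with an expected range of 150 nM to 800 nM.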

Compound 3, concentration for 50% growth inhibition: 2240 nM
For compound 3 the middle estimate is 6.4-fold (0.81 log units) below the measured one; the whole stated range lies below it.
By their numbers in this assay, from the lowest: compounds 1 and 2 (each within the scatter of the next); then compound 3.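

In this assay the dimethylamino group at the end of the chain counts: hydrogen in its place brings a 6.1-fold higher number from compound 2 to compound 3 (0.78 log units; beyond the scatter) and leaves a plain propyl chain on the sulfur. The chain with its dimethylamino group matched methylamino within the scatter, but propylsulfanyl in place of methylamino gives a 7.5-fold higher number from compound 1 to compound 3 (0.87 log units; beyond the scatter) as the step. No supporting evidence accounts for this loss. Still open, from the compounds shown here alone, is whether another end group, such as a hydroxyl or a morpholine, would serve as well. A shorter or longer chain carrying dimethylamino also remains to be read.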